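The source may report more compounds than this note shows. Statements on the series, on what has been measured and on what is new or still open speak of the compounds shown alone.

Measured in a functional assay on MCF7 cells (Homo sapiens) for inhibition, read by MTT assay, with a stated time of 72 h (a higher number here means a weaker inhibitor, a lower number a stronger inhibitor), so far
- compound 1 `O=C(O)CCCCCCC(=O)Nc1ccc(C2=C(c3ccc(O)cc3)C3CC(S(=O)(=O)Oc4cccc5ccccc45)C2O3)cc1` gives 4700 nM
- compound 2 `Cc1ccc(OS(=O)(=O)C2CC3OC2C(c2ccc(NC(=O)CCCCCCC(=O)O)cc2)=C3c2ccc(O)cc2)cc1` gives 60500 nM

Compound 2 has the higher of the two numbers, at 60500 nM. Compound 3 `O=C(O)CCCCCCC(=O)Nc1ccc(C2=C(c3ccc(O)cc3)C3CC(S(=O)(=O)Oc4ccc(C(F)(F)F)cc4)C2O3)cc1` differs from it by trifluoromethyl in place of methyl on an aromatic carbon, with trifluoromethyl in place of methyl on an aromatic carbon, para to a large group. Among the compounds with values here, only one measured step bears on this, a 13-fold higher number from compound 1 to compound 2 (1.11 log units; beyond the scatter), and it changes the whole group on the same oxygen, so it is a loose guide. A moderate move toward a lower number is expected, and the estimated change is a 3.0-fold lower number from compound 2 to compound 3 (0.48 log units; beyond the scatter) as a working figure. Compound 3 is estimated at 20000 nM, within an expected range of 5000 nM to 70000 nM.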

Compound 3, half-maximal inhibitory concentration: 24000 nM
Compound 3: the middle estimate sits 1.2-fold (0.08 log units) below what was measured; low and high end bracket the measured number.
By their numbers in this assay, from the lowest: compound 1; then compound 3; then compound 2.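

In this assay, trifluoromethyl in place of methyl, para to a large group, gives a 2.5-fold lower number from compound 2 to compound 3 (0.40 log units; beyond the scatter) and so shows that this one position responds to a change much smaller than replacing the whole group. Naphthalen-1-yl still keeps the lowest number, with a 5.1-fold higher number from compound 1 to compound 3 (0.71 log units; beyond the scatter) on going to 4-(trifluoromethyl)phenyl. No measurement at hand accounts for either step.

On these data alone, whether chlorine, a methoxy group or a nitrile at the same place would lower the number further remains open. So does whether a substituent on naphthalen-1-yl would shift it in the same direction.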